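This account rests on a few compounds, and the source may have more. Where it says the series, first, only, none or still open, it means among the compounds named here.

Three compounds share one core and differ only in the group on a saturated chain carbon two bonds along the chain from an amide-type nitrogen. Compound 1 `CCCCCCCCCCCCCC[C@H](OCOC)[C@H](CO)NC(=O)OC(C)(C)C` carries a hydroxy there, and in a functional assay on MDA-MB-231 cells (Homo sapiens) for antiproliferative activity, read by sulforhodamine B assay, with a stated time of 48 h, tested at 10 uM (a higher number here means more inhibition at the concentration tested (going by the name of the read-out), a lower number less inhibition), compound 1 gives -5.67%. Compound 2 `CCCCCCCCCCCCCC[C@H](OCOC)[C@H](CN(CCCC)CCCC)NC(=O)OC(C)(C)C` carries a dibutylamino group instead, and compound 2 gives 22.3%, the highest of the three numbers. Compound 3 `CCCCCCCCCCCCCC[C@H](OCOC)[C@H](CN1CCCCC1)NC(=O)OC(C)(C)C` carries a piperidin-1-yl group, and compound 3 gives 9.84%. The measured steps are a number 28 percentage points higher from compound 1 to compound 2 (beyond the scatter), a number 15.5 percentage points higher from compound 1 to compound 3 (beyond the scatter) and a number 12.5 percentage points lower from compound 2 to compound 3 (beyond the scatter), so each exchange at that carbon moved the read-out beyond the scatter, though only modestly.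

Compound 4 `CCCCCCCCCCCCCC[C@H](O)[C@H](CN(CCCC)CCCC)NC(=O)OC(C)(C)C` keeps the dibutylamino group of compound 2 but is altered at a different place: hydrogen in place of methoxymethyl on an oxygen on a saturated carbon. None of the three measured steps touches this oxygen; all of them concern the amine end of the chain, so the weight of methoxymethoxy against hydroxy at this position has not been tested. Without a comparable step to lean on, the expectation is no movement beyond the scatter, which means a step of a number 0.3 percentage points lower from compound 2 to compound 4 (within the scatter). Compound 4 is therefore estimated at 22%, within a deliberately wide range from 2% to 42%.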

Compound 4, a percentage reported as inhibition, at one concentration (the size of the read-out at that concentration, not a potency): -9.61%
The estimate for compound 4 lay 31.6 percentage points above the measured number, and the stated range ends above it.
By their numbers in this assay, from the lowest: compounds 4 and 1 (each within the scatter of the next); then compound 3; then compound 2.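

Going by these compounds alone, until this point, only the amine end of the chain had been varied, so the oxygen on a saturated carbon is the first other place seen to affect the read-out: in this assay, exchanging methoxymethoxy for hydroxy gives a number 31.9 percentage points lower from compound 2 to compound 4 (beyond the scatter) with dibutylamino kept in place. The dibutylamino group alone therefore does not secure the number seen for compound 2, and this pair shows that, with that amine present, the read-out depends on whether methoxymethyl or hydrogen sits on the oxygen. The data give no explanation for how the loss of methoxymethyl produces so large a step.

The compounds shown leave open which part of the methoxymethyl matters, for instance whether a plain methyl, an acetyl or a longer ethoxymethyl group on the same oxygen would keep the number of compound 2 or lose it. They also leave open whether the same exchange would give a step of similar size with piperidin-1-yl, or with another amine such as morpholine, at the end of the chain.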